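The source may hold more compounds than are shown below. What is called first, only, known or untested is meant among the compounds shown, and "the series" means these compounds.

Of the compounds shown here, two of one shared core have so far been tested for how much they harm human cells. Compound 1, `CCC1(Cc2ccccc2)OS(=O)(=O)C=C1OCc1ccc(F)cc1`, was run in an ADME assay on HEL cells (Homo sapiens) for cytotoxicity, with a stated time of 3 days; on this read-out lower numbers stand for higher toxicity in this test and higher numbers for lower toxicity in this test. In this assay compound 1 shows only a limit, >= 50000 nM, and no exact number. Compound 2, `CCC1(Cc2ccccc2)OS(=O)(=O)C=C1OC(c1ccccc1)c1ccccc1`, also returns only a limit in this assay, >= 80000 nM. Both values therefore sit at a limit, as the lines the limit of >= 50000 nM in this assay, at which 1 of the 2 values shown sits, and the limit of >= 80000 nM in this assay, at which 1 of the 2 values shown sits, record, so compound 1 cannot be placed above or below compound 2 on these numbers; all that can be said is that neither harmed the cells within the tested range.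

Compound 3, `CCC1(Cc2ccccc2)OS(=O)(=O)C=C1OCC1CCCCC1`, has not yet been measured in this assay. It differs from compound 1 by cyclohexyl in place of 4-fluorophenyl on a saturated chain carbon bound to an oxygen on an unsaturated carbon. Within the data shown here, with no measured pair to compare, no direction beyond the scatter is expected for this change, and the step from compound 1 to compound 3 in this assay is estimated at a step that the limit leaves unreadable from compound 1 to compound 3. Compound 3 is expected to give 60000 nM, most likely between 25000 nM and 150000 nM, and quite possibly again only a limit.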

Compound 3, minimum cytotoxic concentration: >= 200000 nM
Compound 3 gave a limit, no number; the forecaster's own chance of this, stated with the estimate: 75%; at least 3.3-fold (0.52 log units) between middle value and limit.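

Compound 1 and compound 3 each give only a limit in this assay, so the step between them, cyclohexyl in place of 4-fluorophenyl, cannot be read. The compounds shown leave open at what concentration compound 1, compound 2 or compound 3 would harm these cells, and whether the two groups differ at all on this read-out.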